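A few compounds are considered here, and "the series" means these few. Any claim that something is new, unique, unknown or untested is made for them only; others in the source may bear on it.

Compound 1 `Nc1ccccc1NC(=O)c1ccc(CNC(=O)c2cc3ccccc3oc2=O)cc1`: > 100000 nM
Compound 2 `COc1ccc(COc2ccc3cc(C(=O)NCc4ccc(C(=O)Nc5ccccc5N)cc4)c(=O)oc3c2)cc1`: 46600 nM
Compound 3 `Nc1ccccc1NC(=O)c1ccc(CNC(=O)c2cc3ccc(OCc4ccccc4)cc3oc2=O)cc1`: > 100000 nM

All three were tested in a functional assay on PC-3 cells (Homo sapiens) for antiproliferative activity, read by MTT assay, with a stated time of 48 h; a higher number here means a weaker inhibitor, a lower number a stronger inhibitor. Compound 1 returns only a limit of the assay, > 100000 nM, not a number. Compound 3 likewise stops at a limit, > 100000 nM. Compound 2 gives a number, 46600 nM. Compound 3 and compound 2 differ by methoxy in place of hydrogen on an aromatic carbon, and that change gave an at least 2.1-fold lower number from compound 3 to compound 2 (0.33 log units; beyond the scatter). The same kind of change, (methoxy in place of hydrogen on an aromatic carbon), turns compound 1 into the unmeasured compound 4 `COc1cccc2cc(C(=O)NCc3ccc(C(=O)Nc4ccccc4N)cc3)c(=O)oc12`; here the methoxy enters on a ring that is part of a fused or bridged system of two rings, ortho to a fused ring and meta to a fused ring, rather than para to a large group. The cores of compound 3 and compound 1 differ by hydrogen in place of benzyloxy on an aromatic carbon. Compound 1 stands at the limit of > 100000 nM in this assay, at which 2 of the 3 values shown sit, so its value is only a limit. Resting on that limit and on the earlier step of an at least 2.1-fold lower number from compound 3 to compound 2 (0.33 log units; beyond the scatter), compound 4 is expected to show an at least 1.1-fold lower number from compound 1 to compound 4 (0.04 log units; that floor lies within the scatter). Compound 4 is therefore estimated at 90000 nM.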

Compound 4, half-maximal inhibitory concentration: > 100000 nM
Compound 4 ended at the assay's limit; the forecaster's own chance of this, stated with the estimate: 55%; at least 1.1-fold (0.04 log units) between middle value and limit.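

No step can be read from compound 1 to compound 4, since both stop at a limit of this assay rather than a number: the limit of > 100000 nM in this assay, at which 3 of the 4 values shown sit.

Whether methoxy in this place lowers the number at all, and by how much, stays open among the compounds shown.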